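From Chloro to Methyl on Compound 1

A few compounds are considered here, and "the series" means these few. Any claim that something is new, unique, unknown or untested is made for them only; others in the source may bear on it.

In an ADME assay on L6 cells (Rattus norvegicus) for cytotoxicity, read by resazurin assay, with a stated time of 70 h (on this read-out lower numbers stand for stronger inhibition and higher numbers for weaker inhibition), compound 1 `Cc1ccccc1C(=O)Nc1cc(Cl)ccn1` gives 224000 nM as its reading. In this assay compound 2 `Cc1ccc(C(=O)Nc2ccccn2)c(C)c1` gives 283000 nM and compound 3 `Cc1c(C(=O)Nc2ccccn2)ccc(F)c1F` gives 308000 nM as their readings. All three numbers lie within the usual scatter of one another, so compound 1 stands level with the other two and no order can be read among them. No two of these compounds differ in a single place, so no measured step is available as a guide.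

Compound 4 `Cc1ccnc(NC(=O)c2ccccc2C)c1` differs from compound 1 by methyl in place of chloro on an aromatic carbon and nothing else changes. In this assay no step beyond the scatter is expected in either direction. Compound 2 at 283000 nM and compound 3 at 308000 nM carry no chloro, yet they sit within the scatter of compound 1. An estimated step of a 1.1-fold higher number from compound 1 to compound 4 (0.05 log units; within the scatter) is expected to remain within the scatter. For compound 4 the expected value is 250000 nM (estimated range 130000 nM to 400000 nM).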

Compound 4, half-maximal inhibitory concentration: 146000 nM
For compound 4 the middle estimate is 1.7-fold (0.23 log units) above the measured one, within the range that was stated.
By their numbers in this assay, from the lowest: compounds 4, 1, 2 and 3 (each within the scatter of the next, the first and the last beyond it).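

In this assay, methyl in place of chloro on an aromatic carbon opposite the ring nitrogen gives a 1.5-fold lower number from compound 1 to compound 4 (0.19 log units; within the scatter), the first step measured at this position. This single exchange therefore opens no gap beyond the scatter: with methyl instead of chloro at this place, compound 4 stands level with compound 1. No measurement shown gives a reason for this reading.

Going by these compounds, whether an amine or a carboxylic acid on this same aromatic carbon would also stay within the scatter of compound 1 remains open. So does whether methyl in place of chloro would behave in the same way at any other place on the core of compound 1.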